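A few compounds are considered here, and "the series" means these few. Any claim that something is new, unique, unknown or untested is made for them only; others in the source may bear on it.

Three compounds of the series carry numbers in an assay on SH-SY5Y cells for inhibition of Voltage-dependent N-type calcium channel subunit alpha-1B (Homo sapiens), read by FLIPR and calcium flux, with stated times of 600 s and 300 s, in the presence of a further agent that is not named here; a higher number here means a weaker inhibitor, a lower number a stronger inhibitor. Compound 1 `CN(Cc1ccc(OCCCNC(=N)N)cc1)c1nc2ccc(Oc3ccc(C(F)(F)F)cc3)cc2s1` gives 185000 nM, compound 3 `CN(Cc1ccc(OCCCNC(=N)N)cc1)c1nc2ccc(Oc3ccc(O)cc3)cc2s1` gives 432000 nM, and compound 2 `NCCCOc1ccc(CNc2nc3ccc(Oc4ccc(O)cc4)cc3s2)cc1` gives 205000 nM; compound 2 thus stands second highest of the three, close to compound 1 and clearly under compound 3. Compound 4 `NCCCOc1ccc(CNc2nc3ccc(Oc4ccc(F)cc4)cc3s2)cc1` differs from compound 2 by fluoro in place of hydroxy on an aromatic carbon. For the measured compounds named here, the one measured step that bears on this change is a 2.3-fold higher number from compound 1 to compound 3 (0.37 log units; beyond the scatter), in which hydroxy entered in place of trifluoromethyl on the same ring and the number rose modestly. Taking hydroxy away again in favour of fluoro is expected to move the number down by a step of similar size, a 1.9-fold lower number from compound 2 to compound 4 (0.27 log units; within the scatter). Compound 4 is therefore expected at about 110000 nM, with a range of 50000 nM to 250000 nM.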

Compound 4, half-maximal inhibitory concentration: 106000 nM
The estimate for compound 4 lay 1.0-fold (0.02 log units) above the measured number; low and high end bracket the measured number.
By their numbers in this assay, from the lowest: compounds 4, 1 and 2 (each within the scatter of the next); then compound 3.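

With fluoro in place of hydroxy on the aromatic ring of compound 2, the number moves (a 1.9-fold lower number from compound 2 to compound 4 (0.29 log units; within the scatter)), and that step stays within the scatter. At this position, then, the hydrogen-bond donor and acceptor of hydroxy can leave without a change that the assay can separate from scatter, at least in the primary amine compounds. No available data offer a reason for this result. On these data alone, whether an amine or a carboxylic acid here would move the number beyond the scatter remains open. So does the effect of fluoro with the side chain of compound 3.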